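Swapping the ring substituent: methylsulfanyl to trifluoromethyl

The source may report more compounds than this note shows. Statements on the series, on what has been measured and on what is new or still open speak of the compounds shown alone.

Measured compounds:
- compound 1 `COc1ccccc1C#Cc1ccccc1C#CCCCCO`: 22100 nM
- compound 2 `CSc1ccccc1C#Cc1ccccc1C#CCCCCO`: 1500 nM

In a functional assay on SF-295 cells (Homo sapiens) for cytotoxicity (on this read-out lower numbers stand for stronger inhibition of growth and higher numbers for weaker inhibition of growth), compound 2 gives 1500 nM and holds the lowest number of the two measured compounds, with compound 1 as its nearest neighbour. Among the measured compounds shown here, the one measured step, a 15-fold lower number from compound 1 to compound 2 (1.17 log units; beyond the scatter), shows that a change at this one position of the shared core can shift the number a great deal. Compound 3 `OCCCCC#Cc1ccccc1C#Cc1ccccc1C(F)(F)F` carries a different change at the same place: trifluoromethyl in place of methylsulfanyl on an aromatic carbon. For the measured compounds named here, no measured step covers this exact exchange, so the direction of the step from compound 2 to compound 3 in this assay is open; the step from compound 1 to compound 2 only shows that the position is sensitive. A moderate loss is expected as the middle case, a 2.7-fold higher number from compound 2 to compound 3 (0.43 log units; beyond the scatter), with a wide range either way. Compound 3 is therefore estimated at 4000 nM, between 800 nM and 20000 nM.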

Compound 3, concentration for 50% growth inhibition: 2300 nM
Beside the measured number, compound 3's estimate is 1.7-fold (0.24 log units) above it; the range from low to high includes it.
By their numbers in this assay, from the lowest: compounds 2 and 3 (each within the scatter of the next); then compound 1.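

In this assay, putting trifluoromethyl in place of methylsulfanyl gives a 1.5-fold higher number from compound 2 to compound 3 (0.19 log units; within the scatter), so the two groups cannot be told apart at this position, and the sulfur atom is not needed for this level of growth inhibition. Trifluoromethyl in place of methoxy gives a 9.6-fold lower number from compound 1 to compound 3 (0.98 log units; beyond the scatter), which means a second group now improves on methoxy, and compound 1 stands apart from the other two compounds. No measurement shown here explains why methoxy differs from the other two groups. On these data alone, whether an amine or a carboxylic acid on this aromatic carbon would stay level with compound 2 and compound 3, or fall back towards compound 1, remains open. Also open, as far as these compounds go, is how the number would respond to a longer chain at this same place.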